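This account rests on a few compounds, and the source may have more. Where it says the series, first, only, none or still open, it means among the compounds named here.

Of the compounds shown here, three have been measured so far: compound 1 `NS(=O)(=O)c1ccc(C(=O)NNC(=O)c2ccccc2)cc1`, compound 2 `NS(=O)(=O)c1ccc(-c2nnc(-c3ccc(Cl)cc3)o2)cc1` and compound 3 `Cc1ccc(-c2nnc(-c3ccccc3)o2)cc1S(N)(=O)=O`. In an assay on cells for inhibition of Amine oxidase [flavin-containing] B (Homo sapiens), read by fluorescence and spectrophotometry, using microsomes, with a stated time of 20 min (on this read-out higher numbers stand for weaker inhibition and lower numbers for stronger inhibition), compound 1 reaches only the limit of > 100000 nM, which is a limit of the assay and not a number. Compound 2 gives 48 nM. Compound 3 gives 767 nM, the higher of the two numbers, with compound 2 the lower by a gap beyond the usual scatter. The next compound, compound 4 `NS(=O)(=O)c1cc(-c2nnc(-c3ccccc3)o2)ccc1Cl`, differs from compound 3 in one place: chloro in place of methyl on an aromatic carbon. Within the data shown here, no measured pair shows this exchange, so only a small step is expected, one within the scatter in either direction: a 1.5-fold lower number from compound 3 to compound 4 (0.19 log units; within the scatter). On that basis compound 4 is estimated at 500 nM, with a range from 120 nM to 2000 nM.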

Compound 4, half-maximal inhibitory concentration: 439 nM
Compound 4: middle estimate off by 1.1-fold (0.06 log units), on the high side; measured number inside the range.
By their numbers in this assay, from the lowest: compound 2; then compounds 4 and 3 (each within the scatter of the next). At a limit, above all of these: compound 1.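

Among these compounds, this is the first reading at this position, ortho to a sulfamoyl group: in this assay, chloro in place of methyl gives a 1.7-fold lower number from compound 3 to compound 4 (0.24 log units; within the scatter) and so leaves the number within the scatter. At this place, then, these two groups of one heavy atom each cannot be told apart on this read-out. Nothing in the data shown accounts for this result.

As far as these compounds go, what an amine, a carboxylic acid or a longer chain would do at this position remains open. So does whether the same exchange would give a similarly small step with a chloro on the other phenyl ring.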